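A Phenyl Group on the Amine of Compound 1

The source may report more compounds than this note shows. Statements on the series, on what has been measured and on what is new or still open speak of the compounds shown alone.

In a functional assay (microsomes, liver) with Rattus norvegicus as the target (on this read-out lower numbers stand for stronger inhibition and higher numbers for weaker inhibition), compound 1 (`Cc1c(C)c2c(c(C)c1N)CC(C)(C)O2`) gives 760 nM and holds the highest number of the three measured, above compound 2 (`Cc1c(C)c2c(c(C)c1N)CC(C)(CSc1ccccc1)O2`) at 270 nM and compound 3 (`Cc1c(C)c2c(c(C)c1N)CC(C)(CNc1ccccc1)O2`) at 260 nM on this scale. Compound 4 (`Cc1c(C)c2c(c(C)c1Nc1ccccc1)CC(C)(C)O2`) brings phenyl in place of hydrogen on a nitrogen on an aromatic ring and so has phenyl in place of hydrogen on a nitrogen on an aromatic ring. Among the compounds with values here, no measured compound changes that nitrogen. The closest evidence comes from a saturated chain carbon bound to a saturated ring carbon, with modest steps of a 2.8-fold lower number from compound 1 to compound 2 (0.45 log units; beyond the scatter) and a 2.9-fold lower number from compound 1 to compound 3 (0.47 log units; beyond the scatter) there. On that basis, a similarly modest lowering in this assay is expected, though with wide uncertainty. The estimated step is a 2.8-fold lower number from compound 1 to compound 4 (0.45 log units; beyond the scatter) on this reasoning. For compound 4 the estimated value is 270 nM with an expected range from 80 nM to 900 nM in this read-out.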

Compound 4, half-maximal inhibitory concentration: 280 nM
The estimate for compound 4 lay 1.0-fold (0.02 log units) below the measured number; the measured number falls inside the stated range.
By their numbers in this assay, from the lowest: compounds 3, 2 and 4 (each within the scatter of the next); then compound 1.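

In this assay, within the data shown here, phenyl in place of hydrogen on a nitrogen on an aromatic ring gives a 2.7-fold lower number from compound 1 to compound 4 (0.43 log units; beyond the scatter), which shows that this nitrogen, left unchanged in the earlier compounds, also responds to substitution. A modest step is therefore now seen at two places on the core of compound 1, the other being the saturated chain carbon, with a 2.8-fold lower number from compound 1 to compound 2 (0.45 log units; beyond the scatter). Nothing measured here explains the step.

The compounds shown leave open how a methyl, benzyl or acetyl group on this nitrogen would read. They also leave open whether phenyl there and phenylsulfanyl on the chain carbon would together lower the number further.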